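From allyloxy to propargyloxy on a shared core

The compounds below may be only part of what the source reports. "The series", "measured", "known", "first", "only" and "open" are said of these compounds alone.

- Compound 1 `COc1cc(OC)c(-c2coc3cc(OCC=C(C)C)ccc3c2=O)cc1OC` gives 1580 nM
- Compound 2 `C=CCOc1ccc2c(=O)c(-c3cc(OC)c(OC)cc3OC)coc2c1` gives 4750 nM

In a functional assay on A-375 cells (Homo sapiens) for antiproliferative activity, read by MTT assay, with a stated time of 24 h (a higher number here means a weaker inhibitor, a lower number a stronger inhibitor), compound 2 holds the higher of the two numbers, so it is the weaker of the pair. Compound 3 `C#CCOc1ccc2c(=O)c(-c3cc(OC)c(OC)cc3OC)coc2c1` carries one change, (ethynyl in place of vinyl on a saturated chain carbon bound to an oxygen on an aromatic ring), which puts ethynyl in place of vinyl on a saturated chain carbon bound to an oxygen on an aromatic ring. For the measured compounds named here, the only measured step, a 3.0-fold higher number from compound 1 to compound 2 (0.48 log units; beyond the scatter), was modest and replaced 2-methylprop-1-en-1-yl with vinyl, so it bears on this change only loosely. The expected change therefore stays within the scatter, with a 1.1-fold higher number from compound 2 to compound 3 (0.02 log units; within the scatter) as the estimate. The estimated value for compound 3 is 5000 nM, within a range of 2000 nM to 12000 nM.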

Compound 3, half-maximal inhibitory concentration: 3680 nM
Estimate against measurement, compound 3: 1.4-fold (0.13 log units) above; the measured number falls inside the stated range.
By their numbers in this assay, from the lowest: compound 1; then compounds 3 and 2 (each within the scatter of the next).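

In this assay, the change from allyloxy to propargyloxy gives a 1.3-fold lower number from compound 2 to compound 3 (0.11 log units; within the scatter), so at this position the vinyl and ethynyl ends cannot be told apart. The 2-methylprop-1-en-1-yl end of compound 1 stands apart from the ethynyl end too, with a 2.3-fold higher number from compound 1 to compound 3 (0.37 log units; beyond the scatter), as it did from the vinyl end. No evidence is available that would account for either step. The compounds shown leave open whether a longer chain or a terminal amine in this place would shift the number beyond the scatter.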